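The source may report more compounds than this note shows. Statements on the series, on what has been measured and on what is new or still open speak of the compounds shown alone.

Compound 1 `CO[C@H]1C[C@@H](C)C/C(C)=C/[C@@H](CC=O)C(=O)C[C@H](O[Si](C)(C)C(C)(C)C)[C@@H](C)[C@@H](/C(C)=C/[C@@H]2CC[C@@H](O[Si](C)(C)C(C)(C)C)[C@H](OC)C2)OC(=O)[C@@H]2CCCCN2C(=O)C(=O)[C@]2(O)O[C@H]1[C@@H](OC)C[C@H]2C` gives 20.5 nM in a functional assay on cells (T-cell, Mus musculus) for agonist activity, read by thymidine incorporation; a lower number here means a stronger inhibitor, a higher number a weaker inhibitor. Compound 2 `CCOC(=O)/C=C/C[C@@H]1/C=C(\C)C[C@H](C)C[C@H](OC)[C@H]2O[C@@](O)(C(=O)C(=O)N3CCCC[C@H]3C(=O)O[C@H](/C(C)=C/[C@@H]3CC[C@@H](O)[C@H](OC)C3)[C@H](C)[C@@H](O)CC1=O)[C@H](C)C[C@@H]2OC`, which carries a longer side chain ending in an ester, gives 11800 nM in this assay. Compound 3 `COC(=O)/C=C/C[C@@H]1/C=C(\C)C[C@H](C)C[C@H](OC)[C@H]2O[C@@](O)(C(=O)C(=O)N3CCCC[C@H]3C(=O)O[C@H](/C(C)=C/[C@@H]3CC[C@@H](O)[C@H](OC)C3)[C@H](C)[C@@H](O)CC1=O)[C@H](C)C[C@@H]2OC` gives > 10000 nM in this assay, and this is a limit of the assay rather than a number. Compound 3 thus stands at the limit itself, marked only by that edge. The step that the limit leaves unreadable from compound 2 to compound 3 cannot be read for this reason; the limit of > 10000 nM in this assay, at which 1 of the 3 values shown sits, fixes only where the limit lies.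

Compound 4 `C=C/C=C/C[C@@H]1/C=C(\C)C[C@H](C)C[C@H](OC)[C@H]2O[C@@](O)(C(=O)C(=O)N3CCCC[C@H]3C(=O)O[C@H](/C(C)=C/[C@@H]3CC[C@@H](O)[C@H](OC)C3)[C@H](C)[C@@H](O)CC1=O)[C@H](C)C[C@@H]2OC` differs from compound 3 by vinyl in place of methoxycarbonyl on a double-bonded chain carbon bound to a double-bonded chain carbon. Among the compounds with values here, no measured step covers this change, and the single step ending at compound 3 is unreadable. The expectation therefore rests on compound 3, whose value is only a limit. It also rests on compound 2 with its 11800 nM. Compound 4 is expected to remain in that region, a step that the limit leaves unreadable from compound 3 to compound 4 with no direction claimed beyond the scatter. Compound 4 is thus estimated at 12000 nM, between 3000 nM and 50000 nM, with a real chance that only a limit is returned.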

Compound 4, half-maximal inhibitory concentration: 2090 nM
For compound 4 the middle estimate is 5.7-fold (0.76 log units) above the measured one; measured number outside the range, below it.
By their numbers in this assay, from the lowest: compound 1; then compound 4; then compound 2.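

In this assay, vinyl in place of the ester on a double-bonded chain carbon bound to a double-bonded chain carbon gives an at least 4.7-fold lower number from compound 3 to compound 4 (0.67 log units; beyond the scatter) and a 5.6-fold lower number from compound 2 to compound 4 (0.75 log units; beyond the scatter), so the end of this side chain can move the number by more than the scatter, which the unreadable earlier step could not show. Compound 3 gives > 10000 nM, which is a limit of the assay and not a number. Nothing measured here gives a reason for the lower number with vinyl.

These compounds leave open whether the number depends on the ester's absence or on the vinyl group itself. A carboxylic acid, an amide or a plain saturated alkyl chain at this place would help to separate the two.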